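The source may report more compounds than this note shows. Statements on the series, on what has been measured and on what is new or still open speak of the compounds shown alone.

Three compounds share one core, a thioether-linked benzyl bearing trifluoromethyl and an amine-substituted aromatic system. Compound 1 `CCCCCCCCCCCCNc1nc(SCc2ccc(C(F)(F)F)cc2)nc2ccccc12` carries a dodecyl chain on that amine, compound 2 `FC(F)(F)c1ccc(CSc2nc(Nc3ccccc3C(F)(F)F)c3ccccc3n2)cc1` a 2-(trifluoromethyl)phenyl group, and compound 3 `FC(F)(F)c1ccc(CSc2nc(Nc3ccccc3Cl)c3ccccc3n2)cc1` a 2-chlorophenyl group. In a functional assay on PC-3 cells (Homo sapiens) for cytotoxicity, read by MTT assay, with a stated time of 72 h (on this read-out higher numbers stand for weaker inhibition and lower numbers for stronger inhibition), compound 1 gives 26000 nM, compound 2 gives 34800 nM, and compound 3 gives 20400 nM. Compound 3 holds the lowest of the three numbers, but its distance to compound 1 and to compound 2 both lie within the scatter, so no ordering among them is claimed. For the measured compounds named here, the one single-point step, a 1.7-fold lower number from compound 2 to compound 3 (0.23 log units; within the scatter), exchanges one halogen-type substituent for another on the aryl group and stays within the scatter.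

Compound 4 `FC(F)(F)c1ccc(CSc2nc(Nc3cccc(Br)c3)c3ccccc3n2)cc1` is not yet measured. Its difference from compound 3 is 3-bromophenyl in place of 2-chlorophenyl on a nitrogen on an aromatic ring. Going by the values given here, the step from compound 2 to compound 3 is the only measured one touching this aryl group, and it was small; no measured step moves a substituent around the ring. On that basis the expected step of a 1.0-fold lower number from compound 3 to compound 4 (0.01 log units; within the scatter) is none beyond the scatter. Compound 4 is therefore estimated at 20000 nM in this assay, with a range from 7000 nM to 55000 nM.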

Compound 4, half-maximal inhibitory concentration: 8680 nM
Estimate against measurement, compound 4: 2.3-fold (0.36 log units) above, within the range that was stated.
By their numbers in this assay, from the lowest: compound 4; then compounds 3, 1 and 2 (each within the scatter of the next).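

In this assay, the change on the nitrogen now reaches beyond the scatter: replacing 2-chlorophenyl with 3-bromophenyl gives a 2.4-fold lower number from compound 3 to compound 4 (0.37 log units; beyond the scatter), so this aryl group can shift the number, modestly, where the earlier step at this place did not. The same 3-bromophenyl group set against 2-(trifluoromethyl)phenyl gives a 4.0-fold lower number from compound 2 to compound 4 (0.60 log units; beyond the scatter), the larger of the two new steps, and both point the same way, although each swaps the substituent and its place on the ring at once. No measurement shown here accounts for either step.

The compounds shown leave open whether the bromine or its place on the ring carries the step, and a 3-chlorophenyl or a 2-bromophenyl group on the same nitrogen would separate the two. They also leave open whether the lower number extends to other groups at that ring place, such as a methoxy group, an amine or a carboxylic acid, or whether it is confined to the 3-bromophenyl group on this shared core.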